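Replacing the (carboxymethyl)(methyl)amino group of compound 3

The source may report more compounds than this note shows. Statements on the series, on what has been measured and on what is new or still open speak of the compounds shown alone.

In a functional assay on Caco-2 cells (Homo sapiens) for antiproliferative activity, read by MTT assay, with a stated time of 48 h (on this read-out lower numbers stand for stronger inhibition and higher numbers for weaker inhibition), three compounds sharing one core have been measured. Compound 1 `CCn1c(C(=O)NCCN(C)C)ccc1C(CC)(CC)c1ccc(OCCC(O)(CC)CC)c(C)c1` gives 1140 nM, compound 2 `CCOC(=O)CN(C)C(=O)c1ccc(C(CC)(CC)c2ccc(OCCC(O)(CC)CC)c(C)c2)n1CC` gives 30300 nM, and compound 3 `CCn1c(C(=O)N(C)CC(=O)O)ccc1C(CC)(CC)c1ccc(OCCC(O)(CC)CC)c(C)c1` gives 2740 nM, the middle of the three numbers. Compound 4 `CCn1c(C(=O)NC(CO)CCO)ccc1C(CC)(CC)c1ccc(OCCC(O)(CC)CC)c(C)c1` differs from compound 3 on a carbonyl carbon: a group of 7 heavy atoms (4 carbon, 1 nitrogen, 2 oxygen; no ring) in place of a group of 6 heavy atoms (3 carbon, 1 nitrogen, 2 oxygen; no ring), on a carbonyl carbon.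

Among the measured compounds shown here, three measured steps bear on this change. At that same carbonyl carbon, a 2.4-fold higher number from compound 1 to compound 3 (0.38 log units; beyond the scatter), a modest step, whereas a 27-fold higher number from compound 1 to compound 2 (1.42 log units; beyond the scatter), a large one. The third, an 11-fold lower number from compound 2 to compound 3 (1.04 log units; beyond the scatter), is also large, and it swaps ethyl for hydrogen on an oxygen next to a carbonyl group. Compound 4 has no such ethyl, so the modest step is the closer guide. In this assay, a small step at most is therefore expected, with no firm direction and possibly none beyond the scatter. The estimated step is a 1.1-fold lower number from compound 3 to compound 4 (0.04 log units; within the scatter). For compound 4 the expected value is 2500 nM, with an estimated range of 800 nM to 8000 nM.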

Compound 4, half-maximal inhibitory concentration: 40200 nM
Estimate against measurement, compound 4: 16-fold (1.21 log units) below; measured number above the stated range.
By their numbers in this assay, from the lowest: compound 1; then compound 3; then compounds 2 and 4 (each within the scatter of the next).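

In this assay, a 15-fold higher number from compound 3 to compound 4 (1.17 log units; beyond the scatter) shows that a large change can arise at this carbonyl carbon from a group of 7 heavy atoms replacing one of 6, with neither group carrying a net charge, so heavy-atom count and net charge do not predict the outcome here. With a 1.3-fold higher number from compound 2 to compound 4 (0.12 log units; within the scatter) as the comparison, compound 4 stands level with the ethyl ester compound 2, so a large loss is not confined to that ester. The 2-(dimethylamino)ethyl amide keeps the lowest number, and a 35-fold higher number from compound 1 to compound 4 (1.55 log units; beyond the scatter) widens the known span at this position.

Nothing given here accounts for the large step. As far as these compounds go, it remains open whether a 2-hydroxyethyl amide, with a shorter chain and one hydroxyl, would sit nearer compound 3 or compound 4.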